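Cyano in place of hydrogen on the indole-bearing core

This account rests on a few compounds, and the source may have more. Where it says the series, first, only, none or still open, it means among the compounds named here.

Measured in a functional assay on NCI-H1975 cells (Homo sapiens) for antiproliferative activity, read by MTT assay, with a stated time of 72 h; on this read-out lower numbers stand for stronger inhibition and higher numbers for weaker inhibition:
compound 1 `C=C(Cl)C(=O)Nc1cc(Nc2nccc(-c3cn(C)c4ccccc34)n2)c(OC)cc1N(C)CCN(C)C`, 1290 nM
compound 2 `C=C(Cl)C(=O)Nc1cc(Nc2ncc(C#N)c(-c3cn(C)c4ccccc34)n2)c(OC)cc1N(C)CCN(C)C`, 1620 nM
compound 3 `C=CC(=O)Nc1cc(Nc2nccc(-c3cn(C)c4ccc(F)cc34)n2)c(OC)cc1N(C)CCN(C)C`, 254 nM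

Compound 2 differs from compound 1 by cyano in place of hydrogen on an aromatic carbon and this change gave a 1.3-fold higher number from compound 1 to compound 2 (0.10 log units; within the scatter). Compound 4 `C=CC(=O)Nc1cc(Nc2ncc(C#N)c(-c3cn(C)c4ccc(F)cc34)n2)c(OC)cc1N(C)CCN(C)C` is not yet measured; it differs from compound 3 by cyano in place of hydrogen on an aromatic carbon. This is the same kind of change, but the surroundings are not identical: in compound 1 the carbon is ortho to a 1-methyl-1H-indol-3-yl group, in compound 3 it is ortho to a 5-fluoro-1-methyl-1H-indol-3-yl group. The difference between the core of compound 1 and the core of compound 3 is not broken down here; compound 3 stands lowest of the three numbers, with compound 1 its nearest neighbour. For compound 4 the expected step is a 1.3-fold higher number from compound 3 to compound 4 (0.11 log units; within the scatter), resting on the small step seen as a 1.3-fold higher number from compound 1 to compound 2 (0.10 log units; within the scatter). Compound 4 is therefore estimated at 330 nM, with a range of 150 nM to 720 nM.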

Compound 4, half-maximal inhibitory concentration: 11400 nM
Compound 4: the middle estimate sits 35-fold (1.54 log units) below what was measured, and the stated range ends below it.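

In this assay, cyano in place of hydrogen gave a 45-fold higher number from compound 3 to compound 4 (1.65 log units; beyond the scatter), so the small step on the core of compound 1 does not carry over to the core of compound 3: the same change on two cores in this assay, a 1.3-fold higher number (0.10 log units; within the scatter) from compound 1 to compound 2 and a 45-fold higher number (1.65 log units; beyond the scatter) from compound 3 to compound 4, 36-fold (1.55 log units) apart, beyond the scatter of two such steps. In these two pairs, the outcome of this change depends on the surrounding structure, and one core's step cannot stand in for the other's. The cores of compound 1 and compound 3 differ in more than one place, and these pairs do not show which difference matters or how the change would behave on a third core.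

Open, as far as these compounds go, is whether a chlorine, a methyl or an amine on this aromatic carbon would follow cyano on the core of compound 3. Also open, from the compounds shown here alone, is whether the 5-fluoro-1-methyl-1H-indol-3-yl group alone accounts for the gap between the two steps.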